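Heteroaryl Swap on a Bicyclic Amine: Cytotoxicity Outlook

This account rests on a few compounds, and the source may have more. Where it says the series, first, only, none or still open, it means among the compounds named here.

Measured compounds:
compound 1, `C[C@H]1[C@H](NCc2ccc(Cl)s2)C[C@H]2C[C@@H]1C2(C)C`: 25000 nM
compound 2, `Cc1n[nH]cc1CN[C@@H]1C[C@H]2C[C@@H]([C@H]1C)C2(C)C`: > 100000 nM

In an ADME assay on MDCK cells (Canis lupus familiaris) for cytotoxicity, read by microscopy, with a stated time of 48 h (on this read-out higher numbers stand for lower toxicity in this test and lower numbers for higher toxicity in this test), compound 1 gives 25000 nM. Compound 2 reaches only the limit of the measurement, > 100000 nM, so its true number is not known. The single measured step, an at least 4.0-fold higher number from compound 1 to compound 2 (0.60 log units; beyond the scatter), therefore ends at the limit of > 100000 nM in this assay, at which 1 of the 2 values shown sits, and compound 2 stands at the low-toxicity end of the two numbers shown.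

Compound 3, `Cc1csc(CN[C@@H]2C[C@H]3C[C@@H]([C@H]2C)C3(C)C)n1`, differs from compound 2 by 4-methyl-1,3-thiazol-2-yl in place of 3-methyl-1H-pyrazol-4-yl on a saturated chain carbon bound to an amine nitrogen. Among the compounds with values here, only the one measured step bears on this change: it ran toward lower toxicity when the chlorothiophene gave way to the pyrazole, and the entering thiazole again carries a sulfur, as the group in compound 1 did, while losing the donor. Compound 3 is expected to sit somewhat lower than compound 2, a modest step of an at least 2.0-fold lower number from compound 2 to compound 3 (0.30 log units; that floor lies within the scatter), though the limit on compound 2 makes that gap uncertain. Compound 3 is estimated at 50000 nM, within 20000 nM to 150000 nM.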

Compound 3, minimum cytotoxic concentration: > 100000 nM
Compound 3: only a limit was reported (the forecaster's own chance of this, stated with the estimate: 45%); at least 2.0-fold (0.30 log units) between middle value and limit.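

Replacing 5-chlorothiophen-2-yl with 4-methyl-1,3-thiazol-2-yl on a saturated chain carbon bound to an amine nitrogen gives, in this assay, an at least 4.0-fold higher number from compound 1 to compound 3 (0.60 log units; beyond the scatter), so a sulfur in the ring does not by itself keep the number low, and the hydrogen-bond donor of the 3-methyl-1H-pyrazol-4-yl group is not needed to raise it. Compound 3 gives > 100000 nM, which is a limit of the assay and not a number. The step from compound 2 to compound 3 cannot be read because both values end at the same limit: the limit of > 100000 nM in this assay, at which 2 of the 3 values shown sit.

As far as these compounds go, it remains open whether the lower number of compound 1 belongs to the chlorine or to the thiophene ring, a question that a plain thiophen-2-yl group at this place would address. From the compounds shown here alone, how far compound 2 and compound 3 truly lie past the limit is also unknown, so any order between them stays open.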